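Butyl to pyridin-2-yl exchange in the series

The source may hold more compounds than are shown below. What is called first, only, known or untested is meant among the compounds shown, and "the series" means these compounds.

Measured so far in a physicochemical assay for solubility, in phosphate buffer, with a stated time of 18 h; on this read-out lower numbers stand for lower solubility and higher numbers for higher solubility:
- compound 1 `N#Cc1c(N)nc2nc(C3CC3)ncc2c1N` gives 23000 nM
- compound 2 `N#Cc1c(N)nc2nc(C3CCC3)ncc2c1N` gives 217000 nM
- compound 3 `CCCCc1nc(C(C)(C)C)nc2nc(N)c(C#N)c(N)c12` gives 6000 nM

Of the three, compound 3 has the lowest number, with its value of 6000 nM lying beyond the scatter from both others. The next compound is compound 4 `CC(C)(C)c1nc(-c2ccccn2)c2c(N)c(C#N)c(N)nc2n1`, not yet measured. Its difference from compound 3 is pyridin-2-yl in place of butyl on an aromatic carbon, in words pyridin-2-yl in place of butyl on an aromatic carbon.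

Among the measured compounds shown here, only one measured step exists, a 9.4-fold higher number from compound 1 to compound 2 (0.97 log units; beyond the scatter). It is modest but beyond the scatter. It bears on this change only loosely, since neither compound 1 nor compound 2 carries butyl or pyridin-2-yl. It serves as a rough guide to size, not as a precedent. The direction is weakly indicated at best: compound 3 stands low, while compound 1 gives 23000 nM. A modest rise in this assay is therefore expected, with wide uncertainty. The expected step is a 2.3-fold higher number from compound 3 to compound 4 (0.37 log units; beyond the scatter). Compound 4 is estimated at 14000 nM, with an expected range from 3000 nM to 60000 nM.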

Compound 4, solubility: 87000 nM
The estimate for compound 4 lay 6.2-fold (0.79 log units) below the measured number, outside the stated range (above it).
By their numbers in this assay, from the lowest: compound 3; then compound 1; then compound 4; then compound 2.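

In this assay, among the compounds shown here, the step from butyl to pyridin-2-yl is a 15-fold higher number from compound 3 to compound 4 (1.16 log units; beyond the scatter), the first reading of a change at this aromatic carbon next to the ring nitrogen. With the tert-butyl group held constant, the read-out proves strongly sensitive to the group at this position, which compounds 1 and 2 could not show, as their only difference lies elsewhere. The data offer no measured basis for explaining this step.

The two compounds do not separate the contribution of the aromatic ring from that of its ring nitrogen, a distinction that a phenyl group at this carbon would address. From the compounds shown here alone, it also remains open whether the step would hold with cyclopropyl or cyclobutyl in place of the tert-butyl group.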